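Changing the aryl substituent on the shared core

This account rests on a few compounds, and the source may have more. Where it says the series, first, only, none or still open, it means among the compounds named here.

Compound 3 `CS(=O)(=O)c1ccc(-c2cc(C(O)(C(F)(F)F)C(F)(F)F)cnc2N2CCN(S(=O)(=O)c3ccc(N)nc3)CC2)cc1` gives 32 mL.min-1.g-1 in an ADME assay (liver) for metabolic stability, with Liver microsome (Homo sapiens) as the target, using microsomes and NADPH, with a stated time of 30 min, tested at 1 uM; on this read-out higher numbers stand for fast clearance and lower numbers for slow clearance; of the two numbers shown it is the lowest, with compound 1 `Nc1ccc(S(=O)(=O)N2CCN(c3ncc(C(O)(C(F)(F)F)C(F)(F)F)cc3C3CC3)CC2)cn1` nearest at 38 mL.min-1.g-1, a gap within the scatter. Compound 2 `Nc1ccc(S(=O)(=O)N2CCN(c3ncc(C(O)(C(F)(F)F)C(F)(F)F)cc3-c3ccoc3)CC2)cn1` reaches only a limit of the assay, < 14 mL.min-1.g-1. Compound 4 `Nc1ccc(S(=O)(=O)N2CCN(c3ncc(C(O)(C(F)(F)F)C(F)(F)F)cc3-c3ccc4c(c3)CC(=O)N4)CC2)cn1` differs from compound 3 by a group of 10 heavy atoms (8 carbon, 1 nitrogen, 1 oxygen; one five-membered non-aromatic ring with 1 hetero atom, one six-membered aromatic ring of carbon only) in place of a group of 10 heavy atoms (7 carbon, 2 oxygen, 1 sulfur; one six-membered aromatic ring of carbon only), on an aromatic carbon. The steps measured at the same aromatic carbon were an at least 2.7-fold lower number from compound 1 to compound 2 (0.43 log units; beyond the scatter), a 1.2-fold lower number from compound 1 to compound 3 (0.07 log units; within the scatter) and an at least 2.2-fold higher number from compound 2 to compound 3 (0.35 log units; beyond the scatter); the step with furan-3-yl gave the lower number, and 4-(methylsulfonyl)phenyl the higher. A modest lowering is therefore expected for compound 4, of the size a 1.5-fold lower number from compound 3 to compound 4 (0.16 log units; within the scatter). Compound 4 is estimated at 22 mL.min-1.g-1, with a range from 10 mL.min-1.g-1 to 50 mL.min-1.g-1.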

Compound 4, intrinsic clearance in microsomes: < 14 mL.min-1.g-1
Compound 4: only a limit was reported (the forecaster's own chance of this, stated with the estimate: 25%); middle value at least 1.5-fold (0.19 log units) away from the limit.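

At this aromatic carbon, two groups of equal heavy-atom count read differently in this assay, with an at least 2.2-fold lower number from compound 3 to compound 4 (0.35 log units; beyond the scatter), so that count alone does not set the number. Cyclopropyl likewise gives way with an at least 2.7-fold lower number from compound 1 to compound 4 (0.43 log units; beyond the scatter), so a step of this kind is no longer seen with furan-3-yl alone. Compound 4 stands at a limit of the assay, as compound 2 does, so the step between them cannot be read: the limit of < 14 mL.min-1.g-1 in this assay, at which 2 of the 4 values shown sit.

The compounds shown leave open how far below that limit either compound lies. They also leave open how a phenyl group carrying an amine or a carboxylic acid would read at this carbon.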